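Thiophene attachment point on the shared core

The source may hold more compounds than are shown below. What is called first, only, known or untested is meant among the compounds shown, and "the series" means these compounds.

Compound 1 `Nc1nc(N)c2c(-c3ccsc3)cn([C@@H]3O[C@H](CO)[C@@H](O)[C@H]3O)c2n1` in a functional assay on K562 cells (Homo sapiens), read by MTT assay, with a stated time of 72 h (a higher number here means a weaker inhibitor, a lower number a stronger inhibitor), gives > 20000 nM, which is a limit of the assay and not a number.
Compound 2 `COc1nc(N)nc2c1c(-c1ccsc1)cn2[C@@H]1O[C@H](CO)[C@@H](O)[C@H]1O` gives > 20000 nM, again a limit.
Compound 3 `Cc1nc(N)c2c(-c3ccsc3)cn([C@@H]3O[C@H](CO)[C@@H](O)[C@H]3O)c2n1` gives > 20000 nM, again a limit.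

Compound 1 therefore stands only at the limit of this assay, with no number of its own. The two measured steps, a step that the two limits leave unreadable from compound 1 to compound 2 and a step that the two limits leave unreadable from compound 1 to compound 3, are both unreadable, since the limit of > 20000 nM in this assay, at which 3 of the 3 values shown sit, covers every value in the set. Neither step touches the place of the next change.

Compound 4 `Nc1nc(N)c2c(-c3cccs3)cn([C@@H]3O[C@H](CO)[C@@H](O)[C@H]3O)c2n1` differs from compound 1 by thiophen-2-yl in place of thiophen-3-yl on an aromatic carbon. Within the data shown here, no measured step bears on this change; the only guide is that compound 1 sits at the limit. The step from compound 1 to compound 4 is expected to be a step that the limit leaves unreadable from compound 1 to compound 4, with the chance of a real number judged small. For compound 4 the estimate in this assay is 30000 nM, in the range 8000 nM to 120000 nM, most likely reported as a limit once more.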

Compound 4, half-maximal inhibitory concentration: > 20000 nM
Compound 4 was reported as a limit; the forecaster's own chance of this, stated with the estimate: 80%; the middle value is on the limit's open side.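

Compound 4 is again a limit and not a number, as is compound 1, so no new step can be read between them: the limit of > 20000 nM in this assay, at which 4 of the 4 values shown sit.

The compounds shown leave open which change to the shared core, if any, would give a measurable value in this assay.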